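This account rests on a few compounds, and the source may have more. Where it says the series, first, only, none or still open, it means among the compounds named here.

Measured so far:
- compound 1, `COc1ccc(CNCCCNS(=O)(=O)c2cc(C(F)(F)F)cc(C(F)(F)F)c2)cc1OC`: 3500 nM
- compound 2, `O=S(=O)(NCCCNCc1ccc(Cl)c(C(F)(F)F)c1)c1cc(C(F)(F)F)cc(C(F)(F)F)c1`: 3000 nM
- compound 3, `O=S(=O)(NCCCNCc1ccc(Br)cc1)c1cc(C(F)(F)F)cc(C(F)(F)F)c1`: 2900 nM

These three share one core and differ only in the aromatic ring hanging from the benzylamine. In a functional assay on HPAC cells (Homo sapiens) for inhibition, read by MTT assay, with a stated time of 72 h (on this read-out lower numbers stand for stronger inhibition of growth and higher numbers for weaker inhibition of growth), compound 3 gives the lowest of the three numbers, but its separation from the others is small: a 1.0-fold lower number from compound 2 to compound 3 (0.01 log units; within the scatter) and a 1.2-fold lower number from compound 1 to compound 3 (0.08 log units; within the scatter). The change to compound 4, `O=S(=O)(NCCCNCc1ccc(Cl)cc1)c1cc(C(F)(F)F)cc(C(F)(F)F)c1`, is chloro in place of bromo on an aromatic carbon. Among the compounds with values here, every measured step so far swaps substituents on that same ring, and each stayed within the scatter, including a 1.2-fold lower number from compound 1 to compound 2 (0.07 log units; within the scatter). Nothing in these data marks the bromo group as special, so the step of no change at the digits printed from compound 3 to compound 4 (within the scatter) is expected to stay within the scatter. Compound 4 is therefore estimated at 2900 nM, with a likely range from 1500 nM to 5500 nM.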

Compound 4, concentration for 50% growth inhibition: 2800 nM
Estimate against measurement, compound 4: 1.0-fold (0.02 log units) above; low and high end bracket the measured number.
By their numbers in this assay, from the lowest: compounds 4, 3, 2 and 1 (each within the scatter of the next).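

In this assay, chloro and bromo on this aromatic carbon cannot be told apart (a 1.0-fold lower number from compound 3 to compound 4 (0.02 log units; within the scatter)). Two larger differences also stay within the scatter: trifluoromethyl against hydrogen on the same ring (a 1.1-fold lower number from compound 2 to compound 4 (0.03 log units; within the scatter)) and 4-chlorophenyl against 3,4-dimethoxyphenyl (a 1.3-fold lower number from compound 1 to compound 4 (0.10 log units; within the scatter)). No measurement available here offers an explanation for this flat result.

The compounds shown leave open whether an amine or a carboxylic acid on this ring, or a longer chain in the shared core, would give a step beyond the scatter.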